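The compounds below may be only part of what the source reports. "The series", "measured", "known", "first", "only" and "open" are said of these compounds alone.

Measured in an ADME assay on the whole organism (blood) with Mus musculus as the target, with a stated time of 4 h, at a dose of 50 mg/kg by the oral route; on this read-out lower numbers stand for lower exposure and higher numbers for higher exposure at the dose given:
- compound 1 `CNC1(C)CN(c2c(F)cc3c(=O)c(C(=O)O)cn(C4CC4)c3c2F)C1`: 15800 ng.h/mL
- compound 2 `CNC1CN(c2c(F)cc3c(=O)c(C(=O)O)cn(C4CC4)c3c2F)C1`: 32700 ng.h/mL

Compound 2 is the higher of the two at 32700 ng.h/mL. Compound 3 `NCC1CN(c2c(F)cc3c(=O)c(C(=O)O)cn(C4CC4)c3c2F)C1` is unmeasured and carries aminomethyl in place of methylamino on a saturated ring carbon. Among the measured compounds shown here, the only measured step is a 2.1-fold higher number from compound 1 to compound 2 (0.32 log units; beyond the scatter), which is modest and a different change, so it offers only a rough guide to size. For the measured compounds named here, no measured step tests this swap, and the direction is weakly founded. A modest fall is expected, a 1.6-fold lower number from compound 2 to compound 3 (0.21 log units; within the scatter). For compound 3 the estimate is 20000 ng.h/mL, with an expected range of 8000 ng.h/mL to 45000 ng.h/mL.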

Compound 3, area under the concentration-time curve: 1700 ng.h/mL
Compound 3: middle estimate off by 12-fold (1.07 log units), on the high side, and the stated range ends above it.
By their numbers in this assay, from the lowest: compound 3; then compound 1; then compound 2.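

In this assay the saturated ring carbon proves far more sensitive to how the same atoms are joined than the earlier methyl change suggested: aminomethyl in place of methylamino gives a 19-fold lower number from compound 2 to compound 3 (1.28 log units; beyond the scatter), with heavy atoms, donors and acceptors counted the same. The aminomethyl compound also falls well under the methyl-bearing compound, with a 9.3-fold lower number from compound 1 to compound 3 (0.97 log units; beyond the scatter), so the loss outweighs the earlier methyl effect. No evidence here bears on the cause of this drop. Open, as far as these compounds go, is whether a dimethylamino group or a longer aminoethyl chain on that carbon would track compound 2 or compound 3.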